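This account rests on a few compounds, and the source may have more. Where it says the series, first, only, none or still open, it means among the compounds named here.

Measured compounds:

Compound 1, `CNC(=O)c1cc(C(=O)N[C@H]2CC[C@H](O)CC2)n([C@@H](C)c2cccc(Cl)c2)n1`: 235 nm/s
Compound 2, `CNC(=O)c1cc(C(=O)NC2CCOCC2)n([C@@H](C)c2ccccc2)n1`: 270 nm/s
Compound 3, `CNC(=O)c1cc(C(=O)N[C@H]2CC[C@H](O)CC2)c([C@@H](C)c2cccc(OC)c2)o1`: 44 nm/s

In an ADME assay for permeability (a lower number here means that the compound crosses the layer more slowly, a higher number that the compound crosses the layer faster), compound 2 gives the highest of the three numbers. Its nearest neighbour is compound 1, which in this assay gives 235 nm/s, a difference that lies within the scatter of repeated measurements, so no order can be read between these two. Compound 3 stands furthest away: in this assay compound 3 gives 44 nm/s, which is beyond the scatter and clearly lower than compound 2.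

The next compound, compound 4, `CCNC(=O)c1cc(C(=O)NC)nn1[C@@H](C)c1ccccc1`, differs from compound 2 in one place: ethyl in place of oxan-4-yl on an amide-type nitrogen. Within the data shown here, no pair of measured compounds differs in exactly this way, so no measured step tells how this assay responds to it. Among the measured compounds shown here, compound 2 already stands at the top of the three numbers, and nothing among the measured compounds points to a shift beyond the scatter in either direction. The expectation for the step from compound 2 to compound 4 in this assay is therefore a small one, a 1.1-fold higher number from compound 2 to compound 4 (0.05 log units; within the scatter), within the scatter. On that basis compound 4 is expected to give about 300 nm/s in this assay, with a likely range from 150 nm/s to 600 nm/s.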

Compound 4, apparent permeability: 435 nm/s
Beside the measured number, compound 4's estimate is 1.5-fold (0.16 log units) below it; the measured number falls inside the stated range.
By their numbers in this assay, from the lowest: compound 3; then compounds 1, 2 and 4 (each within the scatter of the next).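

Ethyl in place of oxan-4-yl on an amide-type nitrogen is the first one-place change that can be read in this assay, and it gives a 1.6-fold higher number from compound 2 to compound 4 (0.21 log units; within the scatter), so the two compounds cannot be told apart. At this position, oxan-4-yl, with its 6 heavy atoms, its ring and its hydrogen-bond acceptor, can therefore give way to ethyl, with 2 heavy atoms, no ring and no acceptor, without a shift that stands clear of the scatter in this assay, although this rests on a single pair of compounds. Nothing measured here bears on what lies behind this result.

On these data alone, whether a longer chain such as butyl, or a group carrying an amine or a carboxylic acid, on this same nitrogen would move the number beyond the scatter remains open. Among these compounds, also open is whether the exchange of oxan-4-yl for ethyl would read the same way on another core, such as that of compound 3, or alongside a substituted phenyl group such as the one in compound 1.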